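The compounds below may be only part of what the source reports. "The series", "measured", "known", "first", "only" and "open" are said of these compounds alone.

Measured compounds:
- compound 1, `CC#CC(CC(=O)O)c1ccc(OCc2ccn3cc(-c4ccc(C)cc4C)nc3c2)cc1`, gives 503 nM in an assay on isolated protein for agonist activity at Free fatty acid receptor 1 (Homo sapiens); a lower number here means that less compound is needed, a higher number that more compound is needed for the effect
- compound 2, `CC#CC(CC(=O)O)c1ccc(OCc2ccn3cc(-c4ccc(C)cc4)nc3c2)cc1`, gives 618 nM in this assay

Compound 2 stands beside compound 1 on these two numbers: the step of a 1.2-fold higher number from compound 1 to compound 2 (0.09 log units; within the scatter), which removes a methyl from an aromatic carbon of the shared core's aryl group, does not separate the two compounds beyond the scatter.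

Compound 3, `CC#CC(CC(=O)O)c1ccc(OCc2ccn3cc(-c4ccc(CC)cc4)nc3c2)cc1`, has not yet been measured. It differs from compound 2 by methyl in place of hydrogen on a saturated chain carbon bound to an aromatic carbon, so the methyl of compound 2 grows into an ethyl.

Going by the values given here, only one measured step bears on this change, and only loosely: the step of a 1.2-fold higher number from compound 1 to compound 2 (0.09 log units; within the scatter) varies substitution on the same aryl group, but it moves a methyl on an aromatic carbon, not on a saturated chain carbon. That step was within the scatter. On the basis of compound 2 and its value 618 nM, the step of a 1.0-fold lower number from compound 2 to compound 3 (0.01 log units; within the scatter) is expected to stay small. Compound 3 is therefore estimated at 600 nM in this assay, within a range of 300 nM to 1300 nM.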

Compound 3, half-maximal effective concentration: 671 nM
Estimate against measurement, compound 3: 1.1-fold (0.05 log units) below; measured number inside the range.
By their numbers in this assay, from the lowest: compounds 1, 2 and 3 (each within the scatter of the next).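

In this assay, going by these compounds alone, the step of a 1.1-fold higher number from compound 2 to compound 3 (0.04 log units; within the scatter) gives the first reading at this place, a saturated chain carbon bound to an aromatic carbon: growing 4-methylphenyl into 4-ethylphenyl does not separate the two compounds beyond the scatter. The step of a 1.3-fold higher number from compound 1 to compound 3 (0.13 log units; within the scatter) is also within the scatter, and it exchanges 2,4-dimethylphenyl for 4-ethylphenyl, so one added carbon on the chain and a methyl moved off the aromatic ring leave the numbers equally unseparated. Together with the earlier comparison, all three aryl groups on the shared core now give values that this assay cannot tell apart, yet no accompanying finding offers any explanation for this.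

What the compounds shown leave open is whether a longer chain such as propyl, a branched group such as isopropyl or tert-butyl, or a group such as methoxy or an amine at this place would also stay within the scatter. Within the data shown here, it also remains open whether a larger step can be found on this aryl group at all, as the only groups seen here are methyl and ethyl.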